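The source may report more compounds than this note shows. Statements on the series, on what has been measured and on what is new or still open speak of the compounds shown alone.

In a functional assay on K562 cells (Homo sapiens) for cytotoxicity, in the presence of a further agent that is not named here (a higher number here means a weaker inhibitor, a lower number a stronger inhibitor), two compounds have been measured:

Compound 1 `Clc1cccc(-c2cc(-c3ccc(Cl)o3)cc(-c3cccs3)n2)c1`: 19800 nM
Compound 2 `Clc1ccc(-c2cc(-c3cccs3)nc(-c3ccccc3Cl)c2)o1`: 17200 nM

Of these two numbers, compound 1 gives the higher one, but the step of a 1.2-fold lower number from compound 1 to compound 2 (0.06 log units; within the scatter) lies within the scatter, so the two are not really distinguished.

Compound 3 `Clc1cccc(-c2cc(-c3ccc(Cl)o3)cc(-c3ccsc3)n2)c1` has not been measured. It differs from compound 1 in one place: thiophen-3-yl in place of thiophen-2-yl on an aromatic carbon. Going by the values given here, no measured step touches the thiophene; the only measured step, a 1.2-fold lower number from compound 1 to compound 2 (0.06 log units; within the scatter), moved the chlorine on the chlorophenyl group and stayed within the scatter. With nothing pointing either way, compound 3 is expected to sit close to compound 1, with a 1.0-fold lower number from compound 1 to compound 3 (0.02 log units; within the scatter). The estimate for compound 3 is 19000 nM, within 8000 nM to 45000 nM.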

Compound 3, half-maximal inhibitory concentration: 23000 nM
Beside the measured number, compound 3's estimate is 1.2-fold (0.08 log units) below it; the measured number falls inside the stated range.
By their numbers in this assay, from the lowest: compounds 2, 1 and 3 (each within the scatter of the next).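

Replacing thiophen-2-yl with thiophen-3-yl next to the ring nitrogen gives a 1.2-fold higher number from compound 1 to compound 3 (0.07 log units; within the scatter) in this assay. Going by these compounds alone, this is the first look at the thiophene, since the earlier step touched only the chlorophenyl group, and it shows that the two ways of attaching this ring cannot be told apart here. No evidence available here bears on this result. On these data alone, it remains open whether an amine or a carboxylic acid in place of the thiophene would move the number beyond the scatter.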